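This account rests on a few compounds, and the source may have more. Where it says the series, first, only, none or still open, it means among the compounds named here.

Measured compounds in an assay on isolated protein for inhibition of malate dehydrogenase, mitochondrial (Sus scrofa), with stated times of 45 min and 30 min; a lower number here means a stronger inhibitor, a higher number a weaker inhibitor:
- compound 1, `O=S(=O)(Nc1ccc2oc(-c3ccccc3)nc2c1)c1cccc(C(F)(F)F)c1`: compound 1 gives > 63000 nM, which is a limit of the assay.
- compound 2, `COc1cccc(S(=O)(=O)Nc2ccc3oc(-c4ccccc4)nc3c2)c1`: compound 2 gives > 63000 nM, which is a limit of the assay.
- compound 3, `O=S(=O)(Nc1ccc(-c2nc3ccccc3o2)cc1)c1ccc(C(F)(F)F)cc1`: compound 3 gives > 63000 nM, which is a limit of the assay.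

All three values sit at the limit of > 63000 nM in this assay, at which 3 of the 3 values shown sit, so none of them is a number. From compound 1 to compound 2 the change is methoxy in place of trifluoromethyl on an aromatic carbon, and the step that the two limits leave unreadable from compound 1 to compound 2 cannot be read because both ends are limits. Compound 3 and compound 1 are built from the same atoms joined differently; the difference between the two cores is not broken down here.

Compound 4, `COc1ccc(S(=O)(=O)Nc2ccc(-c3nc4ccccc4o3)cc2)cc1`, has not yet been measured in this assay. It differs from compound 3 by methoxy in place of trifluoromethyl on an aromatic carbon. This is the same kind of change as that from compound 1 to compound 2, but the place differs: here the group sits para to a large group, whereas in compound 2 it sits meta to a large group.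

For the measured compounds named here, since compound 3 sits at a limit and the matching step between compound 1 and compound 2 is unreadable, the expected step that the limit leaves unreadable from compound 3 to compound 4 rests only on the fact that every value so far is a limit. Compound 4 is therefore expected to give 100000 nM in this assay, within 30000 nM to 400000 nM, most likely reported again as a limit.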

Compound 4, half-maximal inhibitory concentration: > 63000 nM
Compound 4 gave a limit, no number; the forecaster's own chance of this, stated with the estimate: 85%; the middle value lies beyond the limit too.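

No step can be read from compound 3 to compound 4, as the values of both are limits of the assay and not numbers. The compounds shown leave open how strongly any of them inhibits the enzyme, and whether methoxy in place of trifluoromethyl changes anything in this assay at all, with every value at one limit: the limit of > 63000 nM in this assay, at which 4 of the 4 values shown sit.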